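Adding a Benzylsulfanyl Arm to Compound 1

The source may report more compounds than this note shows. Statements on the series, on what has been measured and on what is new or still open speak of the compounds shown alone.

Compound 1 `Cc1cc(N2CC[C@@H](C)[C@@H](N(C)c3ncnc4[nH]ccc34)C2)n2ncnc2n1` is the unsubstituted member of this small set. In a functional assay on HGC-27 cells (Homo sapiens) for inhibition, read by MTT assay, with a stated time of 72 h (on this read-out higher numbers stand for weaker inhibition and lower numbers for stronger inhibition), compound 1 gives 11300 nM, the lowest of the two numbers obtained; the nearest is compound 3 `Cc1cc(N2CC[C@@H](C)[C@@H](N(C)c3ncnc4[nH]ccc34)C2)n2nc(SCc3ccc([N+](=O)[O-])cc3)nc2n1`, which gives 29400 nM in this assay. Compound 2 `Cc1cc(N2CC[C@@H](C)[C@@H](N(C)c3ncnc4[nH]ccc34)C2)n2nc(SCc3ccc(F)c(Cl)c3)nc2n1` gives > 100000 nM in this assay, which is a limit of the assay and not a number (the limit of > 100000 nM in this assay, at which 1 of the 3 values shown sits).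

Compound 4 `Cc1cc(N2CC[C@@H](C)[C@@H](N(C)c3ncnc4[nH]ccc34)C2)n2nc(SCc3ccc(C(F)(F)F)cc3)nc2n1` has not yet been measured. It differs from compound 1 by (4-(trifluoromethyl)benzyl)sulfanyl in place of hydrogen on an aromatic carbon. Two measured steps from compound 1 bear on this change, each placing a benzylsulfanyl group on the same aromatic carbon: an at least 8.8-fold higher number from compound 1 to compound 2 (0.94 log units; beyond the scatter) and a 2.6-fold higher number from compound 1 to compound 3 (0.42 log units; beyond the scatter). Between the two substituted compounds, an at least 3.4-fold lower number from compound 2 to compound 3 (0.53 log units; beyond the scatter). Both steps from compound 1 thus ran toward weaker inhibition, at modest to at least modest size, so for compound 4 a higher number than for compound 1 is expected, probably falling between the outcomes seen for the two substituted analogues. The step is estimated as a 4.4-fold higher number from compound 1 to compound 4 (0.65 log units; beyond the scatter). Compound 4 is therefore expected to give about 50000 nM in this assay, within a range from 20000 nM to 150000 nM.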

Compound 4, half-maximal inhibitory concentration: 9540 nM
Compound 4: the middle estimate sits 5.2-fold (0.72 log units) above what was measured; the whole stated range lies above it.
By their numbers in this assay, from the lowest: compounds 4 and 1 (each within the scatter of the next); then compound 3. At a limit, above all of these: compound 2.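

In this assay, among the compounds shown here, the earlier compounds suggested that a benzylsulfanyl arm on this aromatic carbon, between two ring nitrogen atoms, costs inhibition, but compound 4 goes against that pattern: a 1.2-fold lower number from compound 1 to compound 4 (0.07 log units; within the scatter). The arm as such therefore need not weaken inhibition, and the outcome changes with the substituents on its benzene ring, as trifluoromethyl in place of nitro gives a 3.1-fold lower number from compound 3 to compound 4 (0.49 log units; beyond the scatter), while 4-(trifluoromethyl)phenyl in place of 3-chloro-4-fluorophenyl gives an at least 10-fold lower number from compound 2 to compound 4 (1.02 log units; beyond the scatter). That last step has only a bound, since compound 2 stands at a limit of the assay and not at a number: the limit of > 100000 nM in this assay, at which 1 of the 4 values shown sits.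

The compounds shown leave open whether any group on this arm can carry inhibition beyond that of compound 1, since compound 4 is the closest approach and remains within the scatter of it. As far as these compounds go, it also remains open how an amine or a carboxylic acid in place of trifluoromethyl would read in this assay, and whether a longer chain between the sulfur and the benzene ring, or an oxygen in place of the sulfur, would keep the value of compound 4.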